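Cyclohexyl in place of fluorophenyl on the oxazole core

The source may hold more compounds than are shown below. What is called first, only, known or untested is meant among the compounds shown, and "the series" means these compounds.

In an ADME assay on microsomes from liver (Homo sapiens) for metabolic stability, with a stated time of 0.5 h, tested at 0.5 mg/mL (a higher number here means that more of the compound is left, a lower number that less of the compound is left), compound 1 `CN(C)C(=O)CNC(=O)c1cc(-c2ccc(F)cc2)no1` gives 84%. Compound 2 `CN(C)C(=O)CCNC(=O)c1cc(-c2cccc(F)c2)no1` is reported only as a limit of this assay, at > 100%, as noted in the limit of > 100% in this assay, at which 1 of the 2 values shown sits. Compound 2 therefore sits at the upper edge of the numbers shown, with no figure behind the limit. Compound 3 `CN(C)C(=O)CCNC(=O)c1cc(C2CCCCC2)no1` differs from compound 2 by cyclohexyl in place of 3-fluorophenyl on an aromatic carbon. The step is expected to be a loss beyond the usual scatter, and compound 3 is estimated at 70%, between 45% and 95%, with an expected step of a number at least 30 percentage points lower from compound 2 to compound 3 (beyond the scatter) in this assay.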

Compound 3, percent of the compound remaining: > 100%
Compound 3: no number, only a limit; the forecaster's own chance of this, stated with the estimate: 10%; at least 30 percentage points between middle value and limit.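

Compound 2 and compound 3 are both reported only as limits in this assay, so no step can be read between them: the limit of > 100% in this assay, at which 2 of the 3 values shown sit.

Going by these compounds, whether cyclohexyl in place of 3-fluorophenyl on an aromatic carbon changes the compound remaining stays open.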